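Para substituent on the distal ring: isopropoxy to tert-butyl

The compounds below may be only part of what the source reports. "The series", "measured", "known", "first", "only" and "open" are said of these compounds alone.

Compound 1 `CN(C)c1ccc(-c2ccc(NC(=O)c3ccccc3)nc2)cc1` is the starting point of this short series. In an assay on isolated protein (Aquatica lateralis) for inhibition of Luciferin 4-monooxygenase (Luciola lateralis), read by a luciferase reporter, tested at 10 uM (a higher number here means more inhibition at the concentration tested (going by the name of the read-out), a lower number less inhibition), compound 1 gives 14%. Compound 2 `CC(C)Oc1ccc(-c2ccc(NC(=O)c3ccccc3)nc2)cc1` carries an isopropoxy group in place of the dimethylamino group; in this assay compound 2 gives 38%. Among the compounds with values here, the step of a number 24 percentage points higher from compound 1 to compound 2 (beyond the scatter) is modest but beyond the scatter, and compound 2 therefore stands highest of the two numbers known so far.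

Compound 3 `CC(C)(C)c1ccc(-c2ccc(NC(=O)c3ccccc3)nc2)cc1` is not yet measured. The change is tert-butyl in place of isopropoxy on an aromatic carbon. Within the data shown here, the only measured step, a number 24 percentage points higher from compound 1 to compound 2 (beyond the scatter), concerns a different pair of groups at the same aromatic carbon; no measured step shows an alkoxy group exchanged for an alkyl group. The step in this assay from compound 2 to compound 3 is therefore expected to stay within the scatter, as a number 3 percentage points lower from compound 2 to compound 3 (within the scatter). For compound 3 the expected inhibition in this assay is 35%, with a range from 15% to 55%.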

Compound 3, a percentage reported as inhibition, at one concentration (the size of the read-out at that concentration, not a potency): 49%
The estimate for compound 3 lay 14 percentage points below the measured number, within the range that was stated.
By their numbers in this assay, from the lowest: compound 1; then compound 2; then compound 3.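

In this assay, a hydrogen-bond acceptor in the group on this aromatic carbon is not required for inhibition: tert-butyl, with the same count of heavy atoms as isopropoxy and no acceptor, gives a number 11 percentage points higher from compound 2 to compound 3 (beyond the scatter). The three groups now form an order with every gap beyond the scatter, and the widest is a number 35 percentage points higher from compound 1 to compound 3 (beyond the scatter), so the choice of group at this carbon clearly moves the read-out. Nothing available explains this order.

Within the data shown here, whether methyl, a cyclohexyl ring or a carboxylic acid at this carbon would fit the same order remains open, since tert-butyl is the only purely carbon group here. Also open, from the compounds shown here alone, is whether the order would hold with a different amide on the shared core.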